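This account rests on a few compounds, and the source may have more. Where it says the series, first, only, none or still open, it means among the compounds named here.

Compound 1 `COC(=O)/C=C/c1cccc(N(Cc2ccc(-c3ccc(C)cc3)cc2)C(=O)NC(C)C)c1` gives 449 nM in an assay on isolated protein with Bile acid receptor (Homo sapiens) as the target; a higher number here means that more compound is needed for the effect, a lower number that less compound is needed.
Compound 2 `COC(=O)/C=C/c1cccc(N(Cc2ccc(-c3cccc(Cl)c3)cc2)C(=O)NC(C)C)c1` gives 1400 nM in this assay.

Among these two compounds, compound 2 stands at the higher number, the step being a 3.1-fold higher number from compound 1 to compound 2 (0.49 log units; beyond the scatter). Compound 3 `COC(=O)/C=C/c1cccc(N(Cc2ccc(-c3cccc(C)c3)cc2)C(=O)NC(C)C)c1` differs from compound 2 by methyl in place of chloro on an aromatic carbon. Among the compounds with values here, only one measured step bears on this change, a 3.1-fold higher number from compound 1 to compound 2 (0.49 log units; beyond the scatter), and it exchanged both the group and its position at once, so it speaks only loosely to a change of the group alone. A modest move toward a lower number is therefore expected, a 1.8-fold lower number from compound 2 to compound 3 (0.24 log units; within the scatter). The estimate for compound 3 is 800 nM, within a range from 350 nM to 1800 nM.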

Compound 3, half-maximal effective concentration: 1330 nM
Compound 3: middle estimate off by 1.7-fold (0.22 log units), on the low side; low and high end bracket the measured number.
By their numbers in this assay, from the lowest: compound 1; then compounds 3 and 2 (each within the scatter of the next).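

Swapping chloro for methyl at this place on the ring gives no readable difference, a 1.1-fold lower number from compound 2 to compound 3 (0.02 log units; within the scatter), so the two groups cannot be told apart here. Moving the methyl from its place in compound 1 to its place in compound 3 does give a step, a 3.0-fold higher number from compound 1 to compound 3 (0.47 log units; beyond the scatter), which separates position from group in a way the earlier step could not. Nothing available explains either result.

On these data alone, whether a methoxy, an amine or a carboxylic acid at this place would match chloro and methyl stays open. So does whether chloro at the methyl's place in compound 1 would match that compound.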